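A few compounds are considered here, and "the series" means these few. Any claim that something is new, unique, unknown or untested is made for them only; others in the source may bear on it.

The three measured compounds share one core and differ only in the ring attached to the carbon that carries a double bond to nitrogen. In a functional assay on PC-3 cells (Homo sapiens) for inhibition (on this read-out higher numbers stand for weaker inhibition and lower numbers for stronger inhibition), compound 2 `Cc1c(C(=O)N/N=C\c2cccc(F)c2O)oc2cccc(O)c12` gives 12700 nM, the lowest of the two plain numbers. Compound 1 `Cc1c(C(=O)N/N=C\c2ccccc2C(F)(F)F)oc2cccc(O)c12` gives 26200 nM in this assay. Compound 3 `Cc1c(C(=O)N/N=C\c2ccco2)oc2cccc(O)c12` gives >= 40000 nM in this assay. That value is a limit of the assay rather than a number, and it is the limit of >= 40000 nM in this assay, at which 1 of the 3 values shown sits.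

For the measured compounds named here, the one step that can be followed, an at least 3.1-fold higher number from compound 2 to compound 3 (0.49 log units; beyond the scatter), shows that exchanging the ring of compound 2 can weaken inhibition by a clearly measurable margin. Compound 4 `COc1cccc(/C=N\NC(=O)c2oc3cccc(O)c3c2C)c1` differs from compound 2 by 3-methoxyphenyl in place of 3-fluoro-2-hydroxyphenyl on a carbon with a double bond to nitrogen. Going by the values given here, no measured compound carries a 3-methoxyphenyl, and compound 1, with its own different ring, sits above compound 2. A modest rise is therefore expected, and the step from compound 2 to compound 4 is estimated at a 2.0-fold higher number from compound 2 to compound 4 (0.29 log units; within the scatter). Compound 4 is expected to give about 25000 nM in this assay, within a range from 10000 nM to 60000 nM.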

Compound 4, half-maximal inhibitory concentration: >= 40000 nM
Compound 4: no number, only a limit; the forecaster's own chance of this, stated with the estimate: 30%; middle value at least 1.6-fold (0.20 log units) away from the limit.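

In this assay compound 4 gives >= 40000 nM, which is a limit of the assay and not a number. Both 3-fluoro-2-hydroxyphenyl and 3-methoxyphenyl have 8 heavy atoms and one six-membered aromatic ring of carbon only, yet this exchange produces an at least 3.1-fold higher number from compound 2 to compound 4 (0.49 log units; beyond the scatter), so weaker inhibition at this position is not special to the furan-2-yl of compound 3. Compound 3 and compound 4 now sit at the same limit, and the step between them cannot be read: the limit of >= 40000 nM in this assay, at which 2 of the 4 values shown sit.

The compounds shown do not separate the contribution of the hydroxy group of compound 2 from that of its fluorine. On these data alone, whether a phenyl ring carrying an amine or a carboxylic acid at this position would strengthen or weaken inhibition also remains open.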